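Chromene chalcones against colon cancer cells: a hydroxyphenyl variant

The compounds below may be only part of what the source reports. "The series", "measured", "known", "first", "only" and "open" are said of these compounds alone.

Compound 1 `COc1ccc(C(=O)/C=C/c2ccc3ccccc3c2)c2c1C=CC(C)(C)O2`: 2140 nM
Compound 2 `COc1ccc(C(=O)/C=C/c2cccc([N+](=O)[O-])c2)c2c1C=CC(C)(C)O2`: 4090 nM
Compound 3 `COc1ccc(C(=O)/C=C/c2ccc(OC)c(OC)c2OC)c2c1C=CC(C)(C)O2`: > 10000 nM

Of the compounds shown here, three sharing one core have been tested in a functional assay on SW-620 cells (Homo sapiens) for antiproliferative activity, read by MTT assay, with a stated time of 24 h; on this read-out higher numbers stand for weaker inhibition and lower numbers for stronger inhibition. Compound 1 gives 2140 nM in this assay, and compound 2 gives 4090 nM; compound 2 carries the highest of the two numbers, but the gap to compound 1 lies within the scatter, so the two cannot be told apart. For compound 3 the result is a limit rather than a number, namely > 10000 nM, and the limit of > 10000 nM in this assay, at which 1 of the 3 values shown sits, marks the edge of what this assay reports.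

Compound 4 `COc1ccc(C(=O)/C=C/c2ccc(O)cc2)c2c1C=CC(C)(C)O2` has not yet been measured. It differs from compound 2 by 4-hydroxyphenyl in place of 3-nitrophenyl on a double-bonded chain carbon bound to a double-bonded chain carbon. Among the measured compounds shown here, no pair of measured compounds differing in one place has been recorded, so the size of this step cannot be read from the data. Compound 4 is expected to give about 5000 nM in this assay, within 2000 nM to 15000 nM. The expected step of a 1.2-fold higher number from compound 2 to compound 4 (0.09 log units; within the scatter) would be none beyond the scatter.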

Compound 4, half-maximal inhibitory concentration: > 10000 nM
Compound 4 was reported as a limit; the forecaster's own chance of this, stated with the estimate: 25%; at least 2.0-fold (0.30 log units) between middle value and limit.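

In this assay, 4-hydroxyphenyl in place of 3-nitrophenyl on a double-bonded chain carbon bound to a double-bonded chain carbon gives an at least 2.4-fold higher number from compound 2 to compound 4 (0.38 log units; beyond the scatter). Among the compounds shown here, this is the first step that can be read at this position, and it shows that the aryl group here can change the result beyond the scatter. Compound 4 is reported only as a limit, > 10000 nM, so the full size of the step stays unknown, and compound 4 joins compound 3 at the edge of what can be read: the limit of > 10000 nM in this assay, at which 2 of the 4 values shown sit.

Whether the step belongs to the arrival of the hydroxy group or to the departure of the nitro group cannot be told from these compounds. On these data alone, how an aminophenyl or a carboxyphenyl group at this place would read in this assay also stays open.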